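The compounds below may be only part of what the source reports. "The series", "measured", "known", "first", "only" and "open" are said of these compounds alone.

Measured so far in a functional assay on the whole organism (stomach) with Rattus norvegicus as the target; a higher number here means that more compound is needed for the effect, a lower number that less compound is needed
- compound 1 `O=C(O)c1cc(NC(=O)c2ccc([N+](=O)[O-])cc2)cc(C(=O)O)c1` gives 61.1 mg/kg
- compound 2 `N#Cc1cccc(C(=O)Nc2cc(C(=O)O)cc(C(=O)O)c2)c1` gives 140 mg/kg

Compound 1 holds the lower of the two numbers in this assay, and compound 2 lies above it by more than the usual scatter. The next step leads to compound 3 `N#Cc1ccc(C(=O)Nc2cc(C(=O)O)cc(C(=O)O)c2)cc1`, which has cyano in place of nitro on an aromatic carbon, para to a large group (cyano in place of nitro on an aromatic carbon). Among the measured compounds shown here, no measured pair shows this exchange directly. For the measured compounds named here, the only guide is that compound 2, which also carries a cyano group, gives 140 mg/kg and so sits higher than compound 1. A modest rise is therefore expected, with the estimated step of a 1.6-fold higher number from compound 1 to compound 3 (0.21 log units; within the scatter) as the working figure, though it may not clear the scatter. Compound 3 is estimated at 100 mg/kg in this assay, with an expected range from 45 mg/kg to 220 mg/kg as its bounds.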

Compound 3, dose for 50% inhibition: 32.1 mg/kg
Estimate against measurement, compound 3: 3.1-fold (0.49 log units) above, outside the stated range (below it).
By their numbers in this assay, from the lowest: compounds 3 and 1 (each within the scatter of the next); then compound 2.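

At this position, on an aromatic carbon para to a large group, nitro and cyano are not separated in this assay: the exchange gives a 1.9-fold lower number from compound 1 to compound 3 (0.28 log units; within the scatter) and leaves the two compounds indistinguishable. Carrying a cyano group does not in itself go with a higher number: compound 2 gives 140 mg/kg and compound 3 gives 32.1 mg/kg and the two differ only in where the cyano group sits on the ring. No measurement at hand speaks to what lies behind these values.

Still open, on these data alone, is whether a group of another kind at this position, such as an amine or a trifluoromethyl group, also stays level with nitro and cyano. The compounds shown also leave open how a position other than these two on the ring responds to any group but cyano.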